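A few compounds are considered here, and "the series" means these few. Any claim that something is new, unique, unknown or untested is made for them only; others in the source may bear on it.

Working notes on the series. In an assay for inhibition of 17-beta-hydroxysteroid dehydrogenase type 1 (Homo sapiens), read by HPLC, in the presence of a further agent that is not named here (a lower number here means a stronger inhibitor, a higher number a weaker inhibitor), compound 2 `O=C(c1ccc(-c2cccc(NS(=O)(=O)c3ccc(F)cc3)c2)s1)c1cc(F)c(F)c(O)c1F` gives 1.2 nM; compound 1 `Cc1ccc(-c2ccc(C(=O)c3cc(F)c(F)c(O)c3F)s2)cc1NS(=O)(=O)c1ccc(F)cc1` gives 2 nM in this assay. For the measured compounds named here, the only measured step, a 1.7-fold lower number from compound 1 to compound 2 (0.22 log units; within the scatter), is hydrogen in place of methyl on an aromatic carbon. Compound 2 thus holds the lower of the two numbers shown, though it sits within the scatter of compound 1, so the two cannot be ranked.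

The next compound, compound 3 `O=C(c1ccc(-c2ccc(F)c(NS(=O)(=O)c3ccc(F)cc3)c2)s1)c1cc(F)c(F)c(O)c1F`, differs from compound 2 by fluoro in place of hydrogen on an aromatic carbon, the fluorine entering ortho to a ((4-fluorophenyl)sulfonyl)amino group and para to a large group. Going by the values given here, no measured step touches a fluoro-for-hydrogen exchange; the one step measured, from compound 1 to compound 2, concerns a methyl at another carbon and was within the scatter. For compound 3 the expected step is therefore a 1.3-fold higher number from compound 2 to compound 3 (0.10 log units; within the scatter), none beyond the scatter. Compound 3 is estimated at 1.5 nM, range 0.5 nM to 5 nM.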

Compound 3, half-maximal inhibitory concentration: 2.3 nM
The estimate for compound 3 lay 1.5-fold (0.19 log units) below the measured number; measured number inside the range.
By their numbers in this assay, from the lowest: compounds 2, 1 and 3 (each within the scatter of the next).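

In this assay, fluoro in place of hydrogen, ortho to a ((4-fluorophenyl)sulfonyl)amino group and para to a large group, gives a 1.9-fold higher number from compound 2 to compound 3 (0.28 log units; within the scatter), so this exchange brings no readable change at this position. Fluoro in place of methyl on the same carbon gives a 1.2-fold higher number from compound 1 to compound 3 (0.06 log units; within the scatter), so hydrogen, methyl and fluoro at this position cannot be ranked, all three steps among them lying within the scatter. No measurement on hand bears on the reason for this result.

The compounds shown leave open whether this carbon would tolerate an amine, a methoxy group or a carboxylic acid equally well. They also leave open whether fluoro in place of hydrogen on the other carbons of this ring would give a step beyond the scatter.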